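Lengthening a Methylamino Group to Butylamino

This account rests on a few compounds, and the source may have more. Where it says the series, first, only, none or still open, it means among the compounds named here.

Three related compounds have been tested in a functional assay on the whole organism with Rattus norvegicus as the target; a higher number here means that more compound is needed for the effect, a lower number that less compound is needed. Compound 1 (`CCOC(=O)C(=O)Nc1ccc(N)cc1C#N`) gives 1 mg/kg and compound 2 (`CCOC(=O)C(=O)Nc1cc(N(C)C)ccc1C#N`) gives 1.9 mg/kg, two values within the usual scatter of each other. Compound 3 (`CCOC(=O)C(=O)Nc1cccc(NC)c1C#N`) gives 0.2 mg/kg, the lowest number of the three and beyond the scatter from both of the others.

Compound 4 (`CCCCNc1cccc(NC(=O)C(=O)OCC)c1C#N`) has not yet been measured. It carries propyl in place of hydrogen on a saturated chain carbon bound to a nitrogen on an aromatic ring, which turns methylamino into butylamino (propyl in place of hydrogen on a saturated chain carbon bound to a nitrogen on an aromatic ring).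

Within the data shown here, no two measured compounds differ in only one place, so the data give no direct guide to this change. Among the measured compounds shown here, compound 3 at 0.2 mg/kg already has the lowest number so far, and a rise seems more likely than a further fall. The expected change is a 2.5-fold higher number from compound 3 to compound 4 (0.40 log units; beyond the scatter), a modest estimated rise with wide uncertainty. For compound 4 the estimated value is 0.5 mg/kg, with an expected range from 0.1 mg/kg to 2.5 mg/kg.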

Compound 4, dose for half-maximal effect: 0.3 mg/kg
Estimate against measurement, compound 4: 1.7-fold (0.22 log units) above; the range from low to high includes it.
By their numbers in this assay, from the lowest: compounds 3 and 4 (each within the scatter of the next); then compounds 1 and 2 (each within the scatter of the next).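

In this assay, turning methylamino into butylamino gives a 1.5-fold higher number from compound 3 to compound 4 (0.18 log units; within the scatter), so the two compounds cannot be told apart. This is the only pair shown that differs in one place, and it indicates that, for this one pair, propyl in place of hydrogen on a saturated chain carbon bound to a nitrogen on an aromatic ring leaves the number within the usual scatter. No measurement of any property of these groups is available to bear on this result.

As far as these compounds go, it remains open whether a longer chain, or a butyl chain ending in an amine or a carboxylic acid, would also keep the number within the scatter. A single pair also cannot show whether the same lengthening would have a similar effect on compound 1 or compound 2.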